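Aryl swap on a spiro-oxindole scaffold: weak antiproliferative activity

A few compounds are considered here, and "the series" means these few. Any claim that something is new, unique, unknown or untested is made for them only; others in the source may bear on it.

Measured compounds:
compound 1 `Cc1ccc2[nH]c3c(c2c1)CC[C@]1(C3=O)[C@@H](c2ccccc2)[C@@H](c2ccccc2)N[C@@]12C(=O)Nc1ccccc12` — 18000 nM
compound 2 `Cc1ccc2[nH]c3c(c2c1)CC[C@]1(C3=O)[C@@H](c2cccs2)[C@@H](c2ccccc2)N[C@@]12C(=O)Nc1ccccc12` — 15000 nM

In a functional assay on A549 cells (Homo sapiens) for antiproliferative activity, read by MTT assay, with a stated time of 48 h (on this read-out lower numbers stand for stronger inhibition and higher numbers for weaker inhibition), compound 2 gives 15000 nM, which is the lowest of the two numbers, though the gap to compound 1 lies within the scatter. In this assay compound 1 gives 18000 nM. Within the data shown here, the single measured step, a 1.2-fold lower number from compound 1 to compound 2 (0.08 log units; within the scatter), shows that replacing phenyl by thiophen-2-yl on the saturated ring carbon changed little.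

Compound 3 `COc1ccc([C@H]2[C@@H](c3ccccc3)N[C@@]3(C(=O)Nc4ccccc43)[C@]23CCc2c([nH]c4ccc(C)cc24)C3=O)cc1` carries a different group at that same carbon: 4-methoxyphenyl in place of thiophen-2-yl on a saturated ring carbon. Among the measured compounds shown here, the only step that bears on this change is the one from compound 1 to compound 2, and it was within the scatter, so another change of the aryl group at this position is expected to leave the number in this assay roughly where it is, with no step beyond the scatter in either direction.

Compound 3 is therefore expected to give about 15000 nM in this assay, within a range of 6000 nM to 40000 nM, a step of no change at the digits printed from compound 2 to compound 3 (within the scatter) that is estimated to stay within the scatter.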

Compound 3, half-maximal inhibitory concentration: 20000 nM
The estimate for compound 3 lay 1.3-fold (0.12 log units) below the measured number; the range from low to high includes it.
By their numbers in this assay, from the lowest: compounds 2, 1 and 3 (each within the scatter of the next).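

The change to 4-methoxyphenyl from thiophen-2-yl in this assay gives a 1.3-fold higher number from compound 2 to compound 3 (0.12 log units; within the scatter) and so extends the flat reading at this saturated ring carbon to a third aryl group, one with a six-membered aromatic ring and more heavy atoms than thiophen-2-yl. Methoxy in place of hydrogen on the phenyl ring gives a 1.1-fold higher number from compound 1 to compound 3 (0.05 log units; within the scatter) as a separate result, showing that this substitution on the aromatic carbon also produces no step beyond the scatter. No supporting measurement offers a reason for these readings.

From the compounds shown here alone, all three compounds carry an aromatic ring at this carbon, so it remains open whether an amine, a carboxylic acid or a longer alkyl chain there would produce a step beyond the scatter in this assay in either direction.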